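Pyridine for Fluorophenyl on Two Chalcone Cores

The source may hold more compounds than are shown below. What is called first, only, known or untested is meant among the compounds shown, and "the series" means these compounds.

Measured so far:
compound 1, `COc1ccc(/C=C/C(=O)c2ccccc2-c2ccc(F)cc2)cc1OC`, 570 nM
compound 2, `COc1ccc(/C=C/C(=O)c2ccccc2-c2ccc(F)nc2)cc1OC`, 1300 nM
compound 3, `COc1cc(C(=O)/C=C/c2ccccc2-c2ccc(F)cc2)ccc1O`, 4200 nM

In a functional assay on SW480 cells (Homo sapiens) for antiproliferative activity, read by sulforhodamine B assay, with a stated time of 48 h (on this read-out lower numbers stand for stronger inhibition and higher numbers for weaker inhibition), compound 1 gives 570 nM and compound 2 gives 1300 nM. The change between them is 6-fluoropyridin-3-yl in place of 4-fluorophenyl on an aromatic carbon, and it made the step of a 2.3-fold higher number from compound 1 to compound 2 (0.36 log units; beyond the scatter). Compound 3 gives 4200 nM in this assay, the highest number of the three; how its core differs from that of compound 1 is not broken down here. Compound 4, `COc1cc(C(=O)/C=C/c2ccccc2-c2ccc(F)nc2)ccc1O`, is not yet measured; it carries the same change on the core of compound 3, (6-fluoropyridin-3-yl in place of 4-fluorophenyl on an aromatic carbon). Beside the earlier step, compound 4 is expected to show a step of roughly the same size, a 2.3-fold higher number from compound 3 to compound 4 (0.35 log units; beyond the scatter), because compound 3 stands at 4200 nM and the step of a 2.3-fold higher number from compound 1 to compound 2 (0.36 log units; beyond the scatter) is the only guide for this change. Compound 4 is therefore estimated at 9500 nM, with a likely span from 4500 nM to 22000 nM.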

Compound 4, half-maximal inhibitory concentration: 8500 nM
The estimate for compound 4 lay 1.1-fold (0.05 log units) above the measured number; the measured number falls inside the stated range.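

In this assay, 6-fluoropyridin-3-yl in place of 4-fluorophenyl gave a 2.0-fold higher number from compound 3 to compound 4 (0.31 log units; beyond the scatter), and this step matches the earlier one on the other core: the same change on two cores in this assay, a 2.3-fold higher number (0.36 log units; beyond the scatter) from compound 1 to compound 2 and a 2.0-fold higher number (0.31 log units; beyond the scatter) from compound 3 to compound 4, 1.1-fold (0.05 log units) apart, within the scatter of two such steps. In these two pairs, then, the change carried from one core to the other with its direction and size preserved, so the core made no visible difference to the step. This rests on two pairs in a single assay and shows neither that the step would hold on a further core nor why the number rises.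

The compounds shown leave open what an amine or a methoxy group in place of the fluorine would do. They also leave open whether a pyridine without fluorine would give a step of the same size.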